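From dimethyl to dichloro on the triazole aryl

A few compounds are considered here, and "the series" means these few. Any claim that something is new, unique, unknown or untested is made for them only; others in the source may bear on it.

Three analogues sharing one core have been examined in a functional assay on A549 cells (Homo sapiens) for antiproliferative activity, read by MTT assay, with a stated time of 48 h; a higher number here means a weaker inhibitor, a lower number a stronger inhibitor. Compound 1 `N#CC1=C(N)Oc2c(N)cc3nc4ccccc4nc3c2C12C(=O)N(Cc1cnnn1-c1ccc(Cl)cc1)c1ccccc12` carries a 4-chlorophenyl on an aromatic nitrogen, and in this assay compound 1 gives only a limit, > 50000 nM. Compound 2 `CCc1cccc(C)c1-n1nncc1CN1C(=O)C2(C(C#N)=C(N)Oc3c(N)cc4nc5ccccc5nc4c32)c2ccccc21` likewise gives only a limit in this assay, > 50000 nM. Compound 3 `Cc1ccc(C)c(-n2nncc2CN2C(=O)C3(C(C#N)=C(N)Oc4c(N)cc5nc6ccccc6nc5c43)c3ccccc32)c1`, with a 2,5-dimethylphenyl at that nitrogen, also reaches only a limit in this assay, > 50000 nM. Compound 3 thus stands where the whole set stands: the limit of > 50000 nM in this assay, at which 3 of the 3 values shown sit. The steps among these three cannot be sized: a step that the two limits leave unreadable from compound 1 to compound 2, a step that the two limits leave unreadable from compound 1 to compound 3 and a step that the two limits leave unreadable from compound 2 to compound 3 all run from one limit to another.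

Compound 4 `N#CC1=C(N)Oc2c(N)cc3nc4ccccc4nc3c2C12C(=O)N(Cc1cnnn1-c1cc(Cl)ccc1Cl)c1ccccc12` differs from compound 3 by 2,5-dichlorophenyl in place of 2,5-dimethylphenyl on an aromatic nitrogen. Since every step that bears on this aryl group, a step that the two limits leave unreadable from compound 1 to compound 2, a step that the two limits leave unreadable from compound 1 to compound 3 and a step that the two limits leave unreadable from compound 2 to compound 3, lies beyond what the limits resolve, no direction can be read for the new change, and compound 4 is expected most likely to return a limit as well, with the step that the limit leaves unreadable from compound 3 to compound 4 expected to remain unreadable. Compound 4 is estimated at 60000 nM, within a range from 20000 nM to 200000 nM.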

Compound 4, half-maximal inhibitory concentration: 10900 nM
The estimate for compound 4 lay 5.5-fold (0.74 log units) above the measured number; measured number outside the range, below it.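

In this assay the aryl group on this aromatic nitrogen proves able to shift the read-out, which the earlier compounds could not show; compound 4 alone gives a number, while the others remain at a limit: the limit of > 50000 nM in this assay, at which 3 of the 4 values shown sit.

Placing 2,5-dichlorophenyl where 2,5-dimethylphenyl stood brings an at least 4.5-fold lower number from compound 3 to compound 4 (0.66 log units; beyond the scatter), so the same substitution places with chlorine in place of methyl give a readable result. The other two changes at this nitrogen bring an at least 4.5-fold lower number from compound 2 to compound 4 (0.66 log units; beyond the scatter) and an at least 4.5-fold lower number from compound 1 to compound 4 (0.66 log units; beyond the scatter), and the second of these shows that the single chlorine of the 4-chlorophenyl in compound 1 did not yield a number, whereas 2,5-dichlorophenyl did.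

Going by these compounds, the full size of these steps stays open, with compound 1, compound 2 and compound 3 held at a limit. On these data alone, whether a 2,5-difluorophenyl or a 2,5-dibromophenyl would also give a number also stays open.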